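Working notes: removing the core methyl of compound 1

A few compounds are considered here, and "the series" means these few. Any claim that something is new, unique, unknown or untested is made for them only; others in the source may bear on it.

Measured so far:
- compound 1 `COc1cc(Nc2nc(C)cc(N(C)C)n2)ccc1F`: > 250000 nM (an assay limit, not a number)
- compound 2 `COc1cc(Nc2nc(C)cc(N3CCCCC3)n2)ccc1F`: 160000 nM

In a physicochemical assay for solubility, read by nephelometry, measured as kinetic solubility (a lower number here means a less soluble compound, a higher number a more soluble compound), compound 1 reaches the assay limit of > 250000 nM; this is a limit, not a measured number, and it marks where compound 1 stands (the limit of > 250000 nM in this assay, at which 1 of the 2 values shown sits). Compound 2 in this assay gives 160000 nM. Going by the values given here, the only measured step, an at least 1.5-fold lower number from compound 1 to compound 2 (0.19 log units; that floor lies within the scatter), concerns the amine and does not touch the methyl.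

Compound 3 `COc1cc(Nc2nccc(N(C)C)n2)ccc1F` differs from compound 1 by hydrogen in place of methyl on an aromatic carbon. No measured step covers loss of a methyl, so nothing shown argues for a move in either direction; with compound 1 already at the limit, a number above the scatter cannot be seen anyway. The expected step is a number no higher from compound 1 to compound 3 (the limit leaves the size open), none beyond the scatter. For compound 3 the estimate in this assay is 250000 nM, within 120000 nM to 500000 nM, most likely reported again as a limit.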

Compound 3, solubility: 160000 nM
The estimate for compound 3 lay 1.6-fold (0.19 log units) above the measured number, and the stated range covers the measured number.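

In this assay, hydrogen in place of methyl on an aromatic carbon next to the ring nitrogen gives an at least 1.5-fold lower number from compound 1 to compound 3 (0.19 log units; that floor lies within the scatter). Going by these compounds alone, this is the first reading at this position, and compound 3 gives 160000 nM, a measured number rather than a limit, which gives later changes at this carbon a usable point of comparison. The true size of the step remains unread, and a change within the scatter cannot be told from a real loss, with compound 1 sitting at a limit: the limit of > 250000 nM in this assay, at which 1 of the 3 values shown sits.

Open, from the compounds shown here alone, is how this assay reads when this carbon carries something other than methyl or hydrogen, such as ethyl, methoxy or a carboxylic acid. Also open, going by these compounds, is whether the same methyl-to-hydrogen change reads alike with piperidin-1-yl in place of dimethylamino.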